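The source may report more compounds than this note shows. Statements on the series, on what has been measured and on what is new or still open speak of the compounds shown alone.

Going by the values given here, compound 1 `Cc1ccccc1OS(=O)(=O)c1ccc(NC(=O)NCCCCl)cc1` gives the highest of the two numbers so far in a functional assay on M21 cells (Homo sapiens) for cytotoxicity, read by sulforhodamine B assay, with a stated time of 48 h (a higher number here means a weaker inhibitor, a lower number a stronger inhibitor), namely 25000 nM. Compound 2 `CCCc1ccccc1OS(=O)(=O)c1ccc(NC(=O)NCCCCl)cc1` gives 13000 nM in this assay, and the step of a 1.9-fold lower number from compound 1 to compound 2 (0.28 log units; within the scatter), ethyl in place of hydrogen on a saturated chain carbon bound to an aromatic carbon, stays within the scatter. Compound 3 `CCNC(=O)Nc1ccc(S(=O)(=O)Oc2ccccc2C)cc1` differs from compound 1 by hydrogen in place of chloromethyl on a saturated chain carbon, two bonds along the chain from an amide-type nitrogen. Among the compounds with values here, no measured step touches this part of the chain, so the only anchor is compound 1 at 25000 nM. A weaker number is expected, a step of a 2.4-fold higher number from compound 1 to compound 3 (0.38 log units; beyond the scatter). Compound 3 is therefore estimated at 60000 nM, with a range from 20000 nM to 200000 nM.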

Compound 3, half-maximal inhibitory concentration: 3100 nM
Compound 3: middle estimate off by 19-fold (1.29 log units), on the high side, outside the stated range (below it).
By their numbers in this assay, from the lowest: compound 3; then compounds 2 and 1 (each within the scatter of the next).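

Cutting 3-chloropropyl back to ethyl moves the number well beyond the scatter in this assay, an 8.1-fold lower number from compound 1 to compound 3 (0.91 log units; beyond the scatter), whereas the earlier step on the other side of the core did not leave the scatter. In this pair, the chlorine-bearing chain end is therefore not needed for cytotoxicity, and its removal gives the stronger number. Nothing available explains this shift.

The change removes one carbon and the chlorine together, so their shares cannot be separated. Going by these compounds, a plain propyl chain or a 2-chloroethyl chain would help separate them, while an amine at the chain end remains open.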